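The source may report more compounds than this note shows. Statements on the series, on what has been measured and on what is new or still open speak of the compounds shown alone.

Compound 1 `O=C1C(Nc2ccc(OC(F)(F)F)cc2)=CC(=O)c2ncncc21` is the stronger of the two compounds measured in a functional assay on MIA PaCa-2 cells (Homo sapiens) for cytotoxicity, read by MTT assay, with a stated time of 72 h (a higher number here means a weaker inhibitor, a lower number a stronger inhibitor), where compound 1 gives 1400 nM. The bare core, compound 2 `O=C1C=CC(=O)c2ncncc21`, gives 9400 nM in this assay, a gap beyond the usual scatter. Compound 3 `O=C1C(Nc2ccc(Oc3ccccc3)cc2)=CC(=O)c2ncncc21` differs from compound 1 in a single place: phenyl in place of trifluoromethyl on an oxygen on an aromatic ring. Among the compounds with values here, no measured pair shows this particular change, so its effect is not known; a step of modest size is expected, in either direction, likely not beyond the scatter. Compound 3 is estimated at 1200 nM in this assay, between 500 nM and 3000 nM, which corresponds to an expected step of a 1.2-fold lower number from compound 1 to compound 3 (0.07 log units; within the scatter).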

Compound 3, half-maximal inhibitory concentration: 3700 nM
Beside the measured number, compound 3's estimate is 3.1-fold (0.49 log units) below it; the measured number lies above the stated range.
By their numbers in this assay, from the lowest: compound 1; then compound 3; then compound 2.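

In this assay, the change from trifluoromethoxy to phenoxy gives a 2.6-fold higher number from compound 1 to compound 3 (0.42 log units; beyond the scatter). The group on this oxygen therefore affects the result, and of the two groups compared here, trifluoromethyl gives the lower number. No available measurement explains this difference. As far as these compounds go, two groups at one place cannot establish a trend, so it remains open how a plain methyl on this oxygen would compare. It is also unknown how an amine in place of the whole trifluoromethoxy would change the number.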